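This account rests on a few compounds, and the source may have more. Where it says the series, first, only, none or still open, it means among the compounds named here.

Values in a functional assay on A2780 cells (Homo sapiens) for antiproliferative activity, read by CellTiter-Glo, with a stated time of 72 h; on this read-out lower numbers stand for stronger inhibition and higher numbers for weaker inhibition:
- compound 1 `C[C@H](NC(=O)c1ncccn1)c1ccc(NC(=O)N2CC(c3cccnc3)C2)cc1`: 36 nM
- compound 2 `CCC(=O)N[C@@H](C)c1ccc(NC(=O)N2CC(c3ccc(N)nc3)C2)cc1`: 58 nM
- compound 3 `C[C@H](NC(=O)c1ncccn1)c1ccc(NC(=O)N2CC(c3cncc(N)c3)C2)cc1`: 340 nM

Compound 3 has the highest number of the three, and compound 2 lies nearest to it. The next structure, compound 4 `CCC(=O)N[C@@H](C)c1ccc(NC(=O)N2CC(c3cncc(N)c3)C2)cc1`, differs from compound 3 as follows: ethyl in place of pyrimidin-2-yl on a carbonyl carbon. This is ethyl in place of pyrimidin-2-yl on a carbonyl carbon. Among the measured compounds shown here, no measured step covers this change. For the measured compounds named here, the one step available, a 9.4-fold higher number from compound 1 to compound 3 (0.98 log units; beyond the scatter), is amino in place of hydrogen on an aromatic carbon, so it bears only indirectly. Compound 2 also carries propanoylamino and gives 58 nM, so a modest move to a lower number in this assay is expected, with low confidence. The expected change is a 1.4-fold lower number from compound 3 to compound 4 (0.13 log units; within the scatter). The estimate for compound 4 is 250 nM, with an expected range of 90 nM to 700 nM.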

Compound 4, half-maximal inhibitory concentration: 770 nM
The estimate for compound 4 lay 3.1-fold (0.49 log units) below the measured number, and the stated range ends below it.
By their numbers in this assay, from the lowest: compounds 1 and 2 (each within the scatter of the next); then compound 3; then compound 4.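

Ethyl in place of pyrimidin-2-yl on a carbonyl carbon is the first measured change at this position, and it gives a 2.3-fold higher number from compound 3 to compound 4 (0.36 log units; beyond the scatter) in this assay. With propanoylamino held constant, 5-aminopyridin-3-yl in place of 6-aminopyridin-3-yl gives a 13-fold higher number from compound 2 to compound 4 (1.12 log units; beyond the scatter), so the larger of the two new steps lies at the aminopyridinyl group. No measurement at hand accounts for either step.

Going by these compounds, whether the carbonyl change gives a similar step with the aminopyridinyl groups of compound 1 or compound 2 remains open. Also open, on these data alone, is how a longer chain or a phenyl ring on that carbonyl carbon would read.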